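The source may hold more compounds than are shown below. What is called first, only, known or untested is meant among the compounds shown, and "the series" means these compounds.

Compound 1 `Cc1ccccc1-n1nncc1CN1C(=O)C2(C(C#N)=C(N)Oc3c2c2nc4ccccc4nc2c2ccccc32)c2ccccc21`: in a functional assay on A549 cells (Homo sapiens) for antiproliferative activity, read by MTT assay, with a stated time of 48 h (a higher number here means a weaker inhibitor, a lower number a stronger inhibitor), compound 1 gives > 50000 nM, which is a limit of the assay and not a number.
Compound 2 `Cc1cccc(-n2nncc2CN2C(=O)C3(C(C#N)=C(N)Oc4c3c3nc5ccccc5nc3c3ccccc43)c3ccccc32)c1`: in this assay compound 2 gives 39600 nM.
Compound 3 `N#CC1=C(N)Oc2c(c3nc4ccccc4nc3c3ccccc23)C12C(=O)N(Cc1cnnn1-c1ccc(F)cc1)c1ccccc12`: in this assay compound 3 gives > 50000 nM, which is again a limit and not a number.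

Going by these compounds, compound 3 therefore stands at the limit of > 50000 nM in this assay, at which 2 of the 3 values shown sit, the highest concentration the test reaches, so its true inhibitory concentration is unknown beyond lying at or past that point. Compound 4 `N#CC1=C(N)Oc2c(c3nc4ccccc4nc3c3ccccc23)C12C(=O)N(Cc1cnnn1-c1ccc(Cl)cc1)c1ccccc12` differs from compound 3 only in one halogen: chloro in place of fluoro on an aromatic carbon.

Two measured steps lead into compound 3: a step that the two limits leave unreadable from compound 1 to compound 3 and an at least 1.2-fold higher number from compound 2 to compound 3 (0.10 log units; that floor lies within the scatter). Both exchange one aryl group on the aromatic nitrogen for another, and both end at the limit, so neither gives a readable size. Among the measured compounds shown here, no measured step swaps one halogen for another, and no step in this set moves a compound clearly away from the limit region. The expected step is therefore none beyond the scatter: a number no higher from compound 3 to compound 4 (the limit leaves the size open). Compound 4 is expected to give about 50000 nM, between 20000 nM and 150000 nM, and it is more likely than not that this assay will again report only a limit for compound 4.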

Compound 4, half-maximal inhibitory concentration: > 50000 nM
Compound 4 ended at the assay's limit (the forecaster's own chance of this, stated with the estimate: 60%); the middle value sits exactly at the limit.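

Chloro in place of fluoro, para to a large group on the phenyl ring carried by the triazole, does not move compound 4 away from the limit region: the limit of > 50000 nM in this assay, at which 3 of the 4 values shown sit. The steps from compound 1 and from compound 3 to compound 4 run between two limits and cannot be read, so this halogen exchange may hide a real difference or none at all. Among the compounds shown here, the one readable step is an at least 1.2-fold higher number from compound 2 to compound 4 (0.10 log units; that floor lies within the scatter), so even compound 2, the only compound here with an actual number, is not set apart from compound 4.

Going by these compounds, what remains open is whether any other group at this place, such as an amine, a methoxy group or a carboxylic acid, could give a clear number in this assay. On these data alone, all four compounds also share the same core, so the effect of a change to that core, or of a longer chain linking it to the triazole, remains unknown.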